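Methyl for methoxy: expected clearance of compound 3

The compounds below may be only part of what the source reports. "The series", "measured", "known", "first", "only" and "open" are said of these compounds alone.

Measured compounds:
compound 1 `COc1cc(C)[nH]c(=O)c1CN1CCc2c(Cl)cc(-c3c(C)noc3C)c(Cl)c2C1=O` — 70 uL/min
compound 2 `COc1cc(C)[nH]c(=O)c1CN1CCc2c(Cl)cc([C@H](O)C3COC3)c(Cl)c2C1=O` — < 8 uL/min

For the measured compounds named here, in an ADME assay on microsomes from liver (Homo sapiens) for metabolic stability, read by LC-MS, using NADPH, with stated times of 10 min and 45 min, tested at 1 uM (a lower number here means slower removal, a higher number faster removal of the compound), compound 1 gives 70 uL/min, the only number so far. Compound 2 returns < 8 uL/min in this assay; that value is a limit of the assay, not a number, as noted in the limit of < 8 uL/min in this assay, at which 1 of the 2 values shown sits. Going by the values given here, the one measured step, an at least 8.7-fold lower number from compound 1 to compound 2 (0.94 log units; beyond the scatter), exchanges a group on an aromatic carbon of the core and says nothing about the six-membered aromatic ring with 1 nitrogen.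

Compound 3 `Cc1cc(C)c(CN2CCc3c(Cl)cc(-c4c(C)noc4C)c(Cl)c3C2=O)c(=O)[nH]1` differs from compound 1 only there: methyl in place of methoxy on an aromatic carbon. Among the compounds with values here, no measured step touches that position, so no direction can be read from the series; the expectation is a step within the scatter, a 1.2-fold lower number from compound 1 to compound 3 (0.07 log units; within the scatter). Compound 3 is therefore estimated at 60 uL/min in this assay, with a range from 25 uL/min to 140 uL/min.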

Compound 3, intrinsic clearance in a liver preparation (reported as CLH), per the amount of preparation that the assay uses: 107 uL/min
Compound 3: the middle estimate sits 1.8-fold (0.25 log units) below what was measured; the range from low to high includes it.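

In this assay this position now has its first reading, and the step is a 1.5-fold higher number from compound 1 to compound 3 (0.18 log units; within the scatter): compound 1 and compound 3 cannot be told apart. For this pair, then, methyl in place of methoxy on the aromatic carbon opposite the ring nitrogen gives no readable change in clearance, and the methoxy oxygen shows no measurable link to the rate of removal. Nothing shown gives a cause for this step.

The compounds shown cover only methoxy and methyl at this position, so it remains open whether an amine or a carboxylic acid there would give a step beyond the scatter. Going by these compounds, it also remains open whether the same exchange would read alike on compound 2, whose value is a limit of the assay.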